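Pyrimidin-2-yl to (furan-2-yl)methyl on a sulfur

A few compounds are considered here, and "the series" means these few. Any claim that something is new, unique, unknown or untested is made for them only; others in the source may bear on it.

Measured in a functional assay on HepG2 cells (Homo sapiens) for cytotoxicity, read by MTT assay, with a stated time of 48 h (a lower number here means a stronger inhibitor, a higher number a weaker inhibitor), so far:
- compound 1 `O=C(CSCc1ccco1)N1N=C(c2cc3ccccc3oc2=O)C[C@@H]1c1ccccc1C(F)(F)F` gives 18000 nM
- compound 2 `O=C(CSc1ccc(Br)cc1)N1N=C(c2cc3ccccc3oc2=O)C[C@@H]1c1ccc(C(F)(F)F)cc1` gives 12700 nM
- compound 3 `O=C(CSc1ncccn1)N1N=C(c2cc3ccccc3oc2=O)C[C@@H]1c1ccc(C(F)(F)F)cc1` gives 4750 nM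

Compound 3 has the lowest number of the three in this assay, and the gaps to compound 1 and compound 2 both lie beyond the scatter. The next compound to consider is compound 4 `O=C(CSCc1ccco1)N1N=C(c2cc3ccccc3oc2=O)C[C@@H]1c1ccc(C(F)(F)F)cc1`, which places (furan-2-yl)methyl in place of pyrimidin-2-yl on a sulfur whose other neighbour is a saturated chain carbon: (furan-2-yl)methyl in place of pyrimidin-2-yl on a sulfur.

Among the compounds with values here, one measured step concerns this same place, a 2.7-fold lower number from compound 2 to compound 3 (0.43 log units; beyond the scatter), and it is modest. It shows that the group on this sulfur can shift the number. Compound 1 carries the same (furan-2-yl)methyl on a sulfur and gives 18000 nM, but it differs from compound 4 elsewhere, so it serves only as a rough guide. Within the data shown here, no measured pair compares the two groups directly. Compound 1 and compound 2 both lack pyrimidin-2-yl and both stand higher than compound 3 , so a modest rise is expected, similar in size to the measured step.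

The expected change is a 2.1-fold higher number from compound 3 to compound 4 (0.32 log units; beyond the scatter), an estimate with wide uncertainty.

The estimated value for compound 4 is 10000 nM, with an expected range from 4500 nM to 22000 nM.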

Compound 4, half-maximal inhibitory concentration: 11200 nM
Beside the measured number, compound 4's estimate is 1.1-fold (0.05 log units) below it; the range from low to high includes it.
By their numbers in this assay, from the lowest: compound 3; then compounds 4, 2 and 1 (each within the scatter of the next).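

In this assay, the step of a 2.4-fold higher number from compound 3 to compound 4 (0.37 log units; beyond the scatter) adds a second comparison beyond the scatter at this sulfur, so pyrimidin-2-yl now stands apart from both other groups tested there with 4-(trifluoromethyl)phenyl on the saturated ring carbon. The step of a 1.1-fold lower number from compound 2 to compound 4 (0.05 log units; within the scatter) lies within the scatter, so (furan-2-yl)methyl and 4-bromophenyl on the sulfur are not separated in this assay, even though their rings differ. Within the data shown here, the first reading at the saturated ring carbon, a 1.6-fold lower number from compound 1 to compound 4 (0.21 log units; within the scatter), also lies within the scatter, so 4-(trifluoromethyl)phenyl and 2-(trifluoromethyl)phenyl are not separated with (furan-2-yl)methyl on the sulfur.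

No accompanying data bear on why pyrimidin-2-yl stands apart from the other two groups. Still open, on these data alone, is whether that separation persists with 2-(trifluoromethyl)phenyl on the saturated ring carbon, and how a pyridin-2-yl, an amine or a carboxylic acid on the sulfur chain would compare with pyrimidin-2-yl.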